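The source may report more compounds than this note shows. Statements on the series, on what has been measured and on what is new or still open speak of the compounds shown alone.

Series on the shared core of compound 1 `O=C(CSc1snnc1-c1ccc(Br)cc1Br)Nc1ccccn1` with varied aryl groups on the amide-type nitrogen, examined in an ADME assay on MT4 cells (Homo sapiens) for cytotoxicity, read by MTT assay, with a stated time of 5 days; on this read-out lower numbers stand for higher toxicity in this test and higher numbers for lower toxicity in this test. Compound 1 gives 42400 nM. For compound 2 `O=C(CSc1snnc1-c1ccc(Br)cc1Br)Nc1ccccc1[N+](=O)[O-]` the result is a limit of the assay, > 235000 nM. For compound 3 `O=C(CSc1snnc1-c1ccc(Br)cc1Br)Nc1ccccc1F` the result is likewise a limit, >= 27800 nM, so compound 3 stands only as a bound and not as a number among the three values. Among the measured compounds shown here, the step of an at least 5.5-fold higher number from compound 1 to compound 2 (0.74 log units; beyond the scatter) is the one readable step; a step that the limit leaves unreadable from compound 1 to compound 3 and a step that the two limits leave unreadable from compound 2 to compound 3 cannot be sized. Compound 4 `Cc1cccc(NC(=O)CSc2snnc2-c2ccc(Br)cc2Br)c1C` differs from compound 3 by 2,3-dimethylphenyl in place of 2-fluorophenyl on an amide-type nitrogen. For the measured compounds named here, no measured step bears directly on this exchange; the aryl exchanges seen so far have left the read-out at or beyond what this assay reports, as with the limit of > 235000 nM in this assay, at which 1 of the 3 values shown sits, and the limit (the limit of >= 27800 nM in this assay, at which 1 of the 3 values shown sits). Compound 4 is therefore expected to sit in the same region, with a step that the limit leaves unreadable from compound 3 to compound 4 not beyond the scatter, estimated at 50000 nM with a range from 20000 nM to 250000 nM.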

Compound 4, half-maximal cytotoxic concentration: 241000 nM
Estimate against measurement, compound 4: 4.8-fold (0.68 log units) below; the measured number falls inside the stated range.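

Compound 4 gives the series its first step with a plain number at both ends: with 2,3-dimethylphenyl in place of pyridin-2-yl on the amide-type nitrogen, this assay shows a 5.7-fold higher number from compound 1 to compound 4 (0.75 log units; beyond the scatter). Among the compounds shown here, the only earlier readable step ends on a limit, so this exchange is the first that can be sized rather than only bounded. Compound 2 and compound 3 remain limits and not numbers, the first of them here: the limit of > 235000 nM in this assay, at which 1 of the 4 values shown sits.

The compound 3 limit is the second: the limit of >= 27800 nM in this assay, at which 1 of the 4 values shown sits.

The steps from compound 2 and from compound 3 to compound 4 cannot be read, so the order among these aryl groups stays open. Also open, as far as these compounds go, is whether a single methyl group, an amine or a carboxylic acid on the phenyl ring would move the read-out the same way.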